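The compounds below may be only part of what the source reports. "The series", "measured", "known", "first", "only" and "open" are said of these compounds alone.

In a functional assay on HL-60 cells (Homo sapiens) for cytotoxicity, read by MTT assay, with a stated time of 96 h (on this read-out lower numbers stand for stronger inhibition and higher numbers for weaker inhibition), compound 1, whose structure is `CC[C@H](N)C(=O)N[C@@H]1C(=O)N2[C@@H](CC[C@@H]1CCNC(=O)NCc1ccccc1)CC[C@H]2C(=O)NC(c1ccccc1)c1ccccc1`, gives 83300 nM. Compound 2, with structure `CC[C@H](NC)C(=O)N[C@@H]1C(=O)N2[C@@H](CC[C@@H]1CCNC(=O)NCc1ccccc1)CC[C@H]2C(=O)NC(c1ccccc1)c1ccccc1`, differs from compound 1 by the change (methyl in place of hydrogen on an amine nitrogen); in this assay compound 2 gives 52200 nM. That change produced the step of a 1.6-fold lower number from compound 1 to compound 2 (0.20 log units; within the scatter). Compound 3, with structure `CCNCC[C@H]1CC[C@H]2CC[C@@H](C(=O)NC(c3ccccc3)c3ccccc3)N2C(=O)[C@H]1NC(=O)[C@@H](N)CC`, differs from compound 1 by the change (ethyl in place of benzylcarbamoyl on an amine nitrogen); in this assay compound 3 gives 62800 nM. The resulting step is a 1.3-fold lower number from compound 1 to compound 3 (0.12 log units; within the scatter). Compound 4, with structure `CCNCC[C@H]1CC[C@H]2CC[C@@H](C(=O)NC(c3ccccc3)c3ccccc3)N2C(=O)[C@H]1NC(=O)[C@H](CC)NC`, is not yet measured. It differs from compound 3 by the change (methyl in place of hydrogen on an amine nitrogen), which is the same change that separated compound 1 from compound 2, made at the same kind of place. The step from compound 3 to compound 4 is expected to be about a 1.6-fold lower number from compound 3 to compound 4 (0.20 log units; within the scatter), resting on the earlier step of a 1.6-fold lower number from compound 1 to compound 2 (0.20 log units; within the scatter). Compound 4 is therefore estimated at 40000 nM, plausibly between 20000 nM and 80000 nM.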

Compound 4, half-maximal inhibitory concentration: 76400 nM
For compound 4 the middle estimate is 1.9-fold (0.28 log units) below the measured one, and the stated range covers the measured number.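

Methyl in place of hydrogen on the amine nitrogen gives a 1.2-fold higher number from compound 3 to compound 4 (0.09 log units; within the scatter) in this assay, and ethyl in place of benzylcarbamoyl gives a 1.5-fold higher number from compound 2 to compound 4 (0.17 log units; within the scatter). Set beside its earlier step, the methyl change carries from one core to the other without a difference that can be told from scatter: the same change on two cores in this assay, a 1.6-fold lower number (0.20 log units; within the scatter) from compound 1 to compound 2 and a 1.2-fold higher number (0.09 log units; within the scatter) from compound 3 to compound 4, 1.9-fold (0.29 log units) apart, within the scatter of two such steps. For the compounds shown here, the same holds for the ethyl change, but with every step inside the scatter, this shows only that neither change moved the number measurably, not that either has an effect of a reliable size or direction: the same change on two cores in this assay, a 1.3-fold lower number (0.12 log units; within the scatter) from compound 1 to compound 3 and a 1.5-fold higher number (0.17 log units; within the scatter) from compound 2 to compound 4, 1.9-fold (0.29 log units) apart, within the scatter of two such steps.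

Going by these compounds, it stays open whether a longer chain such as propyl, or an acetyl group, on this amine nitrogen would shift the number beyond the scatter.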